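The compounds below may be only part of what the source reports. "The series", "measured", "known", "first", "only" and "open" are said of these compounds alone.

In a functional assay on NCI-H1792 cells (Homo sapiens) for cytotoxicity, read by resazurin assay, with a stated time of 72 h (on this read-out lower numbers stand for stronger inhibition and higher numbers for weaker inhibition), compound 1 `COc1cc(/C=C/C(=O)OCCCO[N+](=O)[O-])ccc1OCCCO[N+](=O)[O-]` gives > 50000 nM as its result, and this is a limit of the assay, not a number. Compound 2 `COc1cc(/C=C/C(=O)OCCCO[N+](=O)[O-])ccc1O` has hydrogen in place of 3-(nitrooxy)propyl on an oxygen on an aromatic ring and gives 28500 nM as a true number. Within the data shown here, the only measured step is an at least 1.7-fold lower number from compound 1 to compound 2 (0.24 log units; that floor lies within the scatter) and it is all there is to go on. Compound 3 `O=C(/C=C/c1ccc(OCCCO[N+](=O)[O-])c(O)c1)OCCCO[N+](=O)[O-]` departs from compound 1 in another way: hydrogen in place of methyl on an oxygen on an aromatic ring with hydrogen in place of methyl on an oxygen on an aromatic ring, so methoxy becomes hydroxy. Like compound 2, compound 3 then carries a hydroxy on the ring, but it keeps the 3-(nitrooxy)propyl that compound 2 lacks. The step to compound 2 is therefore only a loose guide. In this assay the expected step is an at least 1.4-fold lower number from compound 1 to compound 3 (0.15 log units; that floor lies within the scatter) and any change is expected towards a lower number, with nothing firmly beyond the scatter, and another limit is possible. The estimated value for compound 3 is 35000 nM with an expected range from 14000 nM to 80000 nM as its upper end.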

Compound 3, half-maximal inhibitory concentration: 6610 nM
The estimate for compound 3 lay 5.3-fold (0.72 log units) above the measured number, outside the stated range (below it).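

In this assay, replacing methoxy with hydroxy while keeping the 3-(nitrooxy)propyl chains gives an at least 7.5-fold lower number from compound 1 to compound 3 (0.87 log units; beyond the scatter). Among these compounds, this is the first change with a floor that clears the scatter: the earlier step at the other ring oxygen, an at least 1.7-fold lower number from compound 1 to compound 2 (0.24 log units; that floor lies within the scatter), could not separate its two compounds, whereas this one shows that the methyl on this oxygen is a real point of sensitivity in the cell read-out. The step is a floor and not an exact size because compound 1 stands at a limit of the assay, not a number: the limit of > 50000 nM in this assay, at which 1 of the 3 values shown sits.

The compounds shown cannot tell whether the gain comes from the free hydroxy itself or simply from losing the methyl, and they give no reason for it. On these data alone, an ethyl or a longer chain on this oxygen, or an amine or a carboxylic acid in place of the hydroxy, could help to separate these readings, while the size of the step remains open until compound 1 has a true number.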